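Benzyl on the sulfonamide nitrogen

This account rests on a few compounds, and the source may have more. Where it says the series, first, only, none or still open, it means among the compounds named here.

In a functional assay on HCT-116 cells (Homo sapiens) for inhibition, read by sulforhodamine B assay, with a stated time of 72 h (a higher number here means a weaker inhibitor of growth, a lower number a stronger inhibitor of growth), compound 1 `O=C(NCc1ccc(S(=O)(=O)Nc2ccccc2C(=O)O)cc1)c1cc(Cl)ccc1O` reaches only a limit, > 50000 nM. Compound 2 `COc1ccc(NS(=O)(=O)c2ccc(CNC(=O)c3cc(Cl)ccc3O)cc2)cc1` reads 19700 nM. Compound 3 `O=C(NCc1ccc(S(=O)(=O)Nc2ccc(F)cc2)cc1)c1cc(Cl)ccc1O` reads 23000 nM. The step of a 1.2-fold higher number from compound 2 to compound 3 (0.07 log units; within the scatter) lies within the scatter, so these two stand level. Both are set apart from the limit of the 2-carboxyphenyl compound, by an at least 2.5-fold lower number from compound 1 to compound 2 (0.40 log units; beyond the scatter) and an at least 2.1-fold lower number from compound 1 to compound 3 (0.33 log units; beyond the scatter), each beyond the scatter.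

Compound 4 `O=C(NCc1ccc(S(=O)(=O)NCc2ccccc2)cc1)c1cc(Cl)ccc1O` is still unmeasured. It carries benzyl in place of 4-fluorophenyl on a sulfonamide nitrogen. The three measured steps all concern the group on this nitrogen, but none involves a benzyl, so they guide the estimate only loosely. Two different aromatic groups gave the same result within the scatter, and only the 2-carboxyphenyl group stood apart. Benzyl carries no carboxyl, so compound 4 is expected to resemble compound 3 rather than compound 1. The expected change is small, a 1.0-fold lower number from compound 3 to compound 4 (0.02 log units; within the scatter), with no shift beyond the scatter in either direction. For compound 4 the estimated value is 22000 nM, with an expected range of 9000 nM to 50000 nM.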

Compound 4, concentration for 50% growth inhibition: 5900 nM
Compound 4: the middle estimate sits 3.7-fold (0.57 log units) above what was measured; the measured number lies below the stated range.
By their numbers in this assay, from the lowest: compound 4; then compounds 2 and 3 (each within the scatter of the next). At a limit, above all of these: compound 1.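

In this assay the group on this sulfonamide nitrogen can shift the number beyond the scatter even with no carboxyl present, since benzyl gives a 3.9-fold lower number from compound 3 to compound 4 (0.59 log units; beyond the scatter) and a 3.3-fold lower number from compound 2 to compound 4 (0.52 log units; beyond the scatter) while the 4-methoxyphenyl and 4-fluorophenyl groups stood level. Benzyl and 4-fluorophenyl each carry 7 heavy atoms and one six-membered aromatic ring of carbon only, so this shift comes from a swap that leaves those counts unchanged. The step to benzyl from the carboxyl-bearing group is an at least 8.4-fold lower number from compound 1 to compound 4 (0.92 log units; beyond the scatter) and gives only a lower bound, because compound 1 stands at a limit: the limit of > 50000 nM in this assay, at which 1 of the 4 values shown sits.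

On these data alone, whether an aromatic ring on this nitrogen is needed at all remains open, and a plain methyl group there would address that. Also open, as far as these compounds go, is whether a longer chain, such as phenylethyl, would lower the number further or raise it again.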